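The compounds below may be only part of what the source reports. "The series", "measured", "known", "first", "only" and "open" are said of these compounds alone.

In a functional assay on L1210 cells (Mus musculus) for antiproliferative activity (a lower number here means a stronger inhibitor, a higher number a weaker inhibitor), the measured compounds give:

- compound 1 `COc1cc(C(=O)c2sc(-c3ccc(I)cc3)cc2N)cc(OC)c1OC`: 400 nM
- compound 2 `COc1cc(C(=O)c2sc(-c3ccccc3)cc2N)cc(OC)c1OC`: 11 nM
- compound 3 `COc1cccc(-c2cc(N)c(C(=O)c3cc(OC)c(OC)c(OC)c3)s2)c1`: 22 nM

Two steps fix where compound 3 stands. One is a 2.0-fold higher number from compound 2 to compound 3 (0.30 log units; within the scatter), and the other is an 18-fold lower number from compound 1 to compound 3 (1.26 log units; beyond the scatter). Compound 3 therefore cannot be told apart from compound 2, while compound 1 lies far above it.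

Compound 4 `COc1ccc(-c2cc(N)c(C(=O)c3cc(OC)c(OC)c(OC)c3)s2)cc1` keeps the shared core and carries 4-methoxyphenyl in place of 3-methoxyphenyl, on the aromatic carbon next to the ring sulfur (4-methoxyphenyl in place of 3-methoxyphenyl on an aromatic carbon). For the measured compounds named here, no measured step makes this exact change. Methoxy in place of hydrogen gave only a 2.0-fold higher number from compound 2 to compound 3 (0.30 log units; within the scatter), so the 3-methoxyphenyl group costs little that can be seen. Going by the values given here, the sole measured group named as a 4-substituted phenyl is the 4-iodophenyl of compound 1, and hydrogen in place of iodo gave a 36-fold lower number from compound 1 to compound 2 (1.56 log units; beyond the scatter). One compound cannot show whether that large step is particular to iodo or would extend to methoxy.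

In this assay, a modest rise is therefore expected, perhaps not beyond the scatter, with a larger rise possible. The expected change is a 1.8-fold higher number from compound 3 to compound 4 (0.26 log units; within the scatter). For compound 4 the estimated value is 40 nM, with an expected range from 10 nM to 200 nM.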

Compound 4, half-maximal inhibitory concentration: 45 nM
For compound 4 the middle estimate is 1.1-fold (0.05 log units) below the measured one, within the range that was stated.
By their numbers in this assay, from the lowest: compounds 2 and 3 (each within the scatter of the next); then compound 4; then compound 1.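

In this assay, with the same atoms joined differently, 4-methoxyphenyl in place of 3-methoxyphenyl on the aromatic carbon next to the ring sulfur gives a 2.0-fold higher number from compound 3 to compound 4 (0.31 log units; beyond the scatter), so where the methoxy sits on this phenyl ring makes a modest difference that lies beyond the scatter. Against the plain phenyl group the change is a 4.1-fold higher number from compound 2 to compound 4 (0.61 log units; beyond the scatter), which separates the 4-methoxyphenyl group from hydrogen, whereas the 3-methoxyphenyl group of compound 3 could not be told apart from compound 2. Against the 4-iodophenyl group the change is an 8.9-fold lower number from compound 1 to compound 4 (0.95 log units; beyond the scatter), so the large rise seen with iodo is not matched in full by methoxy, although both of these 4-substituted phenyl groups stand above the plain phenyl group of compound 2.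

Going by these compounds, with only iodo and methoxy at hand, it stays open whether 4-fluorophenyl, 4-hydroxyphenyl or 4-aminophenyl would lie nearer compound 2 or nearer compound 1. The data shown offer no independent evidence that would explain these differences.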